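Removing the phenyl from a weakly binding amide series

The source may hold more compounds than are shown below. What is called first, only, known or untested is meant among the compounds shown, and "the series" means these compounds.

Compound 1 `CS(=O)(=O)c1ccc(C(=O)NCC(=O)N(Cc2ccccc2)Cc2ccccc2)cc1[N+](=O)[O-]` gives 3600 nM in an assay on isolated protein for inhibition of thyroid hormone receptor beta (Homo sapiens), read by fluorescence polarization; a higher number here means a weaker inhibitor, a lower number a stronger inhibitor.
Compound 2 `CS(=O)(=O)c1ccc(C(=O)NCCCC(=O)N2Cc3ccccc3C2)cc1[N+](=O)[O-]` gives > 60000 nM in this assay, a limit of the assay and not a number.
Compound 3 `CS(=O)(=O)c1ccc(C(=O)NCCCC(=O)N2CCC(c3ccccc3)CC2)cc1[N+](=O)[O-]` gives > 60000 nM in this assay, again a limit of the assay and not a number.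

Compound 3 therefore stands at the limit of > 60000 nM in this assay, at which 2 of the 3 values shown sit, and no number for it is known. Compound 4 `CS(=O)(=O)c1ccc(C(=O)NCCCC(=O)N2CCCCC2)cc1[N+](=O)[O-]` differs from compound 3 by hydrogen in place of phenyl on a saturated ring carbon. No change between two measured compounds of this kind is shown here, so the effect of removing this phenyl is open. Compound 4 is expected to remain at the limit of the assay, with a step that the limit leaves unreadable from compound 3 to compound 4 that is not expected to reach beyond the usual scatter. Compound 4 is thus estimated at 80000 nM, within 20000 nM to 300000 nM.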

Compound 4, half-maximal inhibitory concentration: > 60000 nM
Compound 4: a limit, no number; the forecaster's own chance of this, stated with the estimate: 85%; the middle value is on the limit's open side.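

In this assay, compound 2, compound 3 and compound 4 all give a limit and not a number, so the steps to compound 4 cannot be read. From the compounds shown here alone, whether removing the phenyl changes inhibition at all remains open.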